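The compounds below may be only part of what the source reports. "The series", "measured", "known", "first", "only" and "open" are said of these compounds alone.

Compound 1 `CC(C)(C)n1cc2c(n1)C(=O)CC1(CCN(C(=O)c3cc(-c4ccccc4Cl)nc4ccccc34)CC1)O2` was tested in a functional assay on MDA-MB-231 cells (Homo sapiens) for inhibition, read by MTT assay, with a stated time of 72 h; a higher number here means a weaker inhibitor, a lower number a stronger inhibitor. In this assay compound 1 gives > 10000 nM, which is a limit of the assay rather than a number, so compound 1 stands at the limit of > 10000 nM in this assay, at which 1 of the 2 values shown sits, and its true position is known only as a range. Among the compounds with values here, compound 2 `CC(C)(C)n1cc2c(n1)C(=O)CC1(CCN(C(=O)c3cc(-c4ccccn4)nc4ccccc34)CC1)O2` is the one measured neighbour; in this assay compound 2 gives 8100 nM. Within the data shown here, the step of an at least 1.2-fold lower number from compound 1 to compound 2 (0.09 log units; that floor lies within the scatter) is the only measured step, and its floor lies within the scatter, so it shows little beyond weak inhibition for both compounds.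

Compound 3 `CC(C)(C)n1cc2c(n1)C(=O)CC1(CCN(C(=O)c3cc(N4CCNCC4)nc4ccccc34)CC1)O2` differs from compound 1 by piperazin-1-yl in place of 2-chlorophenyl on an aromatic carbon. Among the measured compounds shown here, no measured step covers this exchange, so the account rests on the weak values of compound 1 and compound 2. Compound 3 is therefore expected to stay near the same range, with a step of a number no higher from compound 1 to compound 3 (the limit leaves the size open) estimated. The estimate for compound 3 is 10000 nM, between 3000 nM and 30000 nM.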

Compound 3, half-maximal inhibitory concentration: 4200 nM
Compound 3: middle estimate off by 2.4-fold (0.38 log units), on the high side, and the stated range covers the measured number.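

Within the data shown here, on the aromatic carbon next to the ring nitrogen, a non-aromatic ring is tolerated as well as an aromatic one: in this assay, piperazin-1-yl in place of 2-chlorophenyl gives an at least 2.3-fold lower number from compound 1 to compound 3 (0.37 log units; beyond the scatter), the first step here that clears the scatter. Set against pyridin-2-yl, the same group gives a 1.9-fold lower number from compound 2 to compound 3 (0.29 log units; within the scatter), so this exchange does not separate piperazin-1-yl from pyridin-2-yl. The step from 2-chlorophenyl has only a floor for its size, and its true size stays unknown: the limit of > 10000 nM in this assay, at which 1 of the 3 values shown sits.

The compounds shown leave open whether the ring nitrogen that carries a hydrogen in piperazin-1-yl matters, which 4-methylpiperazin-1-yl or morpholin-4-yl at this position could test. They also leave open whether an open-chain amine there would take the number lower still.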